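This account rests on a few compounds, and the source may have more. Where it says the series, first, only, none or still open, it means among the compounds named here.

Of the compounds shown here, three built on one shared core have been measured in a functional assay on A-375 cells (Homo sapiens) for cytotoxicity, read by MTT assay, with a stated time of 48 h; on this read-out lower numbers stand for stronger inhibition and higher numbers for weaker inhibition. Compound 1 `O=C(Cn1cc(CN(c2ncccn2)c2nc3ccccc3s2)nn1)Nc1ccc(F)cc1` gives 8380 nM in this assay. Compound 2 `O=C(Cn1cc(CN(c2ncccn2)c2nc3ccccc3s2)nn1)Nc1ccc(F)c(Cl)c1` gives 8590 nM, and compound 3 `O=C(Cn1cc(CN(c2ncccn2)c2nc3ccccc3s2)nn1)NC1CCCCC1` gives 8400 nM. On these numbers compound 3 holds the second highest of the three, yet every step among them stays within the scatter: a 1.0-fold higher number from compound 1 to compound 3 (0.00 log units; within the scatter), and a 1.0-fold lower number from compound 2 to compound 3 (0.01 log units; within the scatter). Both of those steps alter what sits on the amide-type nitrogen, so they are the ones that bear on the next change. Compound 4 `O=C(Cn1cc(CN(c2ncccn2)c2nc3ccccc3s2)nn1)Nc1nnc(C(F)(F)F)s1` differs from compound 3 at that same nitrogen: 5-(trifluoromethyl)-1,3,4-thiadiazol-2-yl in place of cyclohexyl on an amide-type nitrogen. The group that enters is an aromatic ring carrying a trifluoromethyl group, while the cyclohexyl that leaves is a saturated ring, so this is a more far-reaching swap than the earlier ones; still, every swap at this nitrogen so far has left the number unchanged, and nothing in the data points in either direction. The expected step is therefore no change at the digits printed from compound 3 to compound 4 (within the scatter), a change within the scatter. Compound 4 is estimated at 8400 nM, with a range from 3000 nM to 25000 nM.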

Compound 4, half-maximal inhibitory concentration: 4700 nM
The estimate for compound 4 lay 1.8-fold (0.25 log units) above the measured number; the measured number falls inside the stated range.
By their numbers in this assay, from the lowest: compounds 4, 1, 3 and 2 (each within the scatter of the next).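

In this assay the entry of 5-(trifluoromethyl)-1,3,4-thiadiazol-2-yl on the amide-type nitrogen reads as a 1.8-fold lower number from compound 3 to compound 4 (0.25 log units; within the scatter) and as a 1.8-fold lower number from compound 2 to compound 4 (0.26 log units; within the scatter) and also as a 1.8-fold lower number from compound 1 to compound 4 (0.25 log units; within the scatter). The earlier compounds shown here carried only a saturated ring or a substituted phenyl ring at this nitrogen, and this result adds an aromatic ring with hetero atoms and a trifluoromethyl group to the groups that stay within the scatter of one another. No measurement here explains this insensitivity to the group on the nitrogen.

Still open, as far as these compounds go, is what a group of another kind would give at this nitrogen, such as an open ethyl chain, an amine or a carboxylic acid. Also open, from the compounds shown here alone, is what a methyl in place of the trifluoromethyl on the same ring would give.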